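Replacing the (piperidin-1-yl)carbonyl group of compound 3

A few compounds are considered here, and "the series" means these few. Any claim that something is new, unique, unknown or untested is made for them only; others in the source may bear on it.

Of the compounds shown here, three sharing one core have been tested in a functional assay (aorta) with Rattus norvegicus as the target; on this read-out higher numbers stand for an effect only at larger amounts of compound and lower numbers for an effect already at smaller amounts. Compound 1 (`COc1ccc(-c2nc(CN(C)C)sc2-c2ccc(OC)cc2)cc1`) gives 8.4 uM, and compound 3 (`COc1ccc(-c2nc(C(=O)N3CCCCC3)sc2-c2ccc(OC)cc2)cc1`) gives 11 uM. Among the compounds with values here, these are the only two readable numbers, so compound 3 stands level with compound 1 within the usual scatter.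

For compound 2 (`COc1ccc(-c2nc(C(=O)N3CCOCC3)sc2-c2ccc(OC)cc2)cc1`) the result is only a limit, < 100 uM. That leaves a step that the limit leaves unreadable from compound 1 to compound 2 and also a step that the limit leaves unreadable from compound 2 to compound 3, so neither helps here.

Compound 4 (`COc1ccc(-c2nc(CCC(=O)O)sc2-c2ccc(OC)cc2)cc1`) has not been measured yet. It carries 2-carboxyethyl in place of (piperidin-1-yl)carbonyl on an aromatic carbon of the five-membered aromatic ring, and the swap in full is 2-carboxyethyl in place of (piperidin-1-yl)carbonyl on an aromatic carbon.

Within the data shown here, only one measured step with a readable size changes the group at this same place. That step is a 1.3-fold higher number from compound 1 to compound 3 (0.12 log units; within the scatter), so no step beyond the scatter is expected in this assay. The expected change is a 1.4-fold higher number from compound 3 to compound 4 (0.13 log units; within the scatter).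

No tested compound carries a 2-carboxyethyl group, and the range is kept wide for that reason. Compound 4 is estimated at 15 uM, with an expected range from 3 uM to 60 uM.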

Compound 4, concentration for half-maximal effect: > 100 uM
Compound 4 was reported as a limit; the forecaster's own chance of this, stated with the estimate: 25%; middle value at least 6.6-fold (0.82 log units) from the limit.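

In this assay, the two readable earlier compounds stood level despite carrying different groups on this aromatic carbon, so the position could have seemed tolerant of change; the 2-carboxyethyl group shows that it is not, with an at least 9.0-fold higher number from compound 3 to compound 4 (0.95 log units; beyond the scatter) and an at least 11-fold higher number from compound 1 to compound 4 (1.07 log units; beyond the scatter). The value of compound 4, > 100 uM, is a limit of the assay and not a number, and it leaves a number no lower from compound 2 to compound 4 (the limit leaves the size open). The steps that touch compound 2 cannot be read, so the comparison rests on compound 1 and compound 3 alone, and on these two the change is one that matters at this place on the five-membered aromatic ring.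

Compound 4 loses the six-membered ring and gains the carboxylic acid in a single swap, and the compounds shown cannot separate these two changes; a plain propyl chain, or a carboxylic acid set directly on the same aromatic carbon, is the kind of group that could. Nothing shown gives a measured reason for the result.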